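The compounds below may be only part of what the source reports. "The series", "measured", "known", "first", "only" and "open" are said of these compounds alone.

Compound 2, whose structure is `CC(C)(C)c1ccc(C(=O)N/N=C/c2cc(O)cc(O)c2)cc1`, is examined in a physicochemical assay, read by spectrophotometry, with a stated time of 60 min, tested at 300 uM (on this read-out higher numbers stand for a stronger effect at the one concentration tested and lower numbers for a weaker effect), where it gives 20.1%. Compound 1, with the structure `COc1ccc(/C=C/C=N/NC(=O)c2ccc(O)cc2)cc1`, gives 2.6% in this assay. Among the compounds with values here, of the two numbers known, the one for compound 2 is the higher, and the gap to compound 1 lies beyond the usual scatter of the method. The two differ in more than one place, so no single change can be tied to that gap.

Compound 3, with the structure `O=C(N/N=C/c1cc(O)cc(O)c1)c1ccc(O)cc1`, has not yet been measured in this assay. It differs from compound 2 in one place: hydroxy in place of tert-butyl on an aromatic carbon. The hydroxy that enters is the same group that compound 1 carries on the corresponding ring. Within the data shown here, with no step between measured compounds available for this change, a step of modest size, downward or none beyond the scatter, is expected; the estimated step is a number 6.1 percentage points lower from compound 2 to compound 3 (within the scatter). For compound 3 the expected reading in this assay is 14%, within a range from 3% to 30%.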

Compound 3, a percentage reported as inhibition, at one concentration (the size of the read-out at that concentration, not a potency): 26.5%
Compound 3: middle estimate off by 12.5 percentage points, on the low side; the range from low to high includes it.
By their numbers in this assay, from the lowest: compound 1; then compounds 2 and 3 (each within the scatter of the next).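

In this assay, hydroxy in place of tert-butyl on an aromatic carbon, para to a large group, comes out as a number 6.4 percentage points higher from compound 2 to compound 3 (within the scatter). Within the data shown here, this is the first single-place comparison, and it shows that exchanging a group of four carbons with no hydrogen-bond donor or acceptor for hydroxy, which has one of each, gives no difference that the method can separate from scatter at this position. No measurement shown here accounts for this outcome.

The compounds shown leave open whether other groups at this place, such as an amine or a carboxylic acid, would also remain within the scatter of compound 2 and compound 3. With each compound read at one concentration only, they also leave open how this comparison would look at other concentrations.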